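Terminal alcohol variation on the triple-bonded carbon of the shared core

The source may hold more compounds than are shown below. What is called first, only, known or untested is meant among the compounds shown, and "the series" means these compounds.

Among the measured compounds shown here, compound 3 `NC(=O)c1cc(Cl)c2c(Cl)c(C#CCO)n([C@H]3CCCNC3)c2n1` carries a hydroxymethyl on the triple-bonded carbon; in a functional assay on KG-1 cells (Homo sapiens) for antiproliferative activity (on this read-out lower numbers stand for an effect already at smaller amounts and higher numbers for an effect only at larger amounts of compound), compound 3 gives 301 nM, the highest of the three numbers measured so far. Compound 1 `COCC(C)(C)C#Cc1c(Cl)c2c(Cl)cc(C(N)=O)nc2n1[C@H]1CCCNC1` gives 219 nM, and compound 2 `CC(O)C#Cc1c(Cl)c2c(Cl)cc(C(N)=O)nc2n1[C@H]1CCCNC1` gives 147 nM. The step of a 1.4-fold higher number from compound 1 to compound 3 (0.14 log units; within the scatter) stays within the scatter, whereas a 2.0-fold higher number from compound 2 to compound 3 (0.31 log units; beyond the scatter) is modest but beyond it.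

Compound 4 `CC(C)(O)C#Cc1c(Cl)c2c(Cl)cc(C(N)=O)nc2n1[C@H]1CCCNC1` is not yet measured. It differs from compound 3 as follows: 1-hydroxy-1-methylethyl in place of hydroxymethyl on a triple-bonded carbon. For the measured compounds named here, two measured steps bear on this. The step of a 2.0-fold higher number from compound 2 to compound 3 (0.31 log units; beyond the scatter) takes one methyl off the saturated chain carbon bound to an oxygen and raises the number; compound 4 puts two methyls onto that same carbon, so it reverses and extends that step. The step of a 1.4-fold higher number from compound 1 to compound 3 (0.14 log units; within the scatter) shows that a larger group at this place, compared with hydroxymethyl, stays within the scatter, so added bulk alone is not expected to cost anything here. A modest lowering of the number in this assay is therefore expected for compound 4, a 2.0-fold lower number from compound 3 to compound 4 (0.30 log units; within the scatter), about the size seen between compound 2 and compound 3 rather than larger. Compound 4 is estimated at 150 nM, with a range from 70 nM to 320 nM.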

Compound 4, half-maximal effective concentration: 302 nM
For compound 4 the middle estimate is 2.0-fold (0.30 log units) below the measured one, and the stated range covers the measured number.
By their numbers in this assay, from the lowest: compounds 2, 1, 3 and 4 (each within the scatter of the next, the first and the last beyond it).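

Among the compounds shown here, the carbon bearing the hydroxy tolerates two added methyls in this assay with no readable change, a 1.0-fold higher number from compound 3 to compound 4 (0.00 log units; within the scatter), which the earlier compounds could not show, and adding one methyl does not predict adding two: the single-methyl compound 2 stands apart from the doubly methylated compound, a 2.1-fold higher number from compound 2 to compound 4 (0.31 log units; beyond the scatter), a modest step, so across these three alcohols the number does not follow the methyl count. With the two methyls kept, exchanging methoxymethyl for hydroxy also stays within the scatter, a 1.4-fold higher number from compound 1 to compound 4 (0.14 log units; within the scatter), so a free hydroxy and a methoxymethyl group on that fully substituted carbon cannot be told apart on this read-out. No measurement shown here offers an explanation for why compound 2 stands apart from the others.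

Open, going by these compounds, is whether the small gap around compound 2 marks a real preference for the 1-hydroxyethyl group or only lies close to the edge of the scatter. Also open is how an amine, a carboxylic acid or a longer chain ending in hydroxy would read on the triple-bonded carbon, since every group shown here carries an oxygen.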